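Chloro next to the ring nitrogen in the bis-aminomethyl series

A few compounds are considered here, and "the series" means these few. Any claim that something is new, unique, unknown or untested is made for them only; others in the source may bear on it.

Compound 2 `c1ccc(NCc2ccc(CNc3ncccn3)cc2)nc1` gives 64% in a functional assay on MDA-MB-231 cells for antagonist activity at C-X-C chemokine receptor type 4 (Homo sapiens), tested at 100 nM (a lower number here means a weaker effect, a higher number a stronger effect of the compound at the concentration tested), the lower of the two numbers recorded so far. Compound 1 `Fc1cccc(NCc2ccc(CNc3cccc(F)n3)cc2)n1` gives 85% in this assay, a gap beyond the scatter. Compound 3 `Clc1cccc(NCc2ccc(CNc3ncccn3)cc2)n1` differs from compound 2 in one place: chloro in place of hydrogen on an aromatic carbon, turning pyridin-2-yl into 6-chloropyridin-2-yl. For the measured compounds named here, no step between measured compounds covers this change, so the expectation rests on the gap between compound 2 and compound 1 and on the size of the added group. A moderate rise is expected, a number 10 percentage points higher from compound 2 to compound 3 (within the scatter). Compound 3 is estimated at 74%, within 58% to 88%.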

Compound 3, a percentage reported as inhibition, at one concentration (the size of the read-out at that concentration, not a potency): 100%
For compound 3 the middle estimate is 26 percentage points below the measured one; the whole stated range lies below it.
By their numbers in this assay, from the lowest: compound 2; then compound 1; then compound 3.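

In this assay, for the compounds shown here, chloro in place of hydrogen next to the ring nitrogen gives a number 36 percentage points higher from compound 2 to compound 3 (beyond the scatter), the first single-place step. A substituent is therefore tolerated at this position of the pyridin-2-yl ring, and one added heavy atom there is enough for a large change. Nothing available accounts for the size of this step. Still open, as far as these compounds go, is whether a methyl, a methoxy or an amine at the same position gives a similar step. Also open, from the compounds shown here alone, is whether chloro on the other terminal ring of compound 3 changes the read-out.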